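Swapping One Hydrogen for Fluorine on a Second Core

A few compounds are considered here, and "the series" means these few. Any claim that something is new, unique, unknown or untested is made for them only; others in the source may bear on it.

Four small molecules share a phenyl ring attached to a bicyclic core that carries an amide, and they were compared in a functional assay on the whole organism (strain Kunming) with Mus musculus as the target; on this read-out lower numbers stand for an effect already at smaller amounts and higher numbers for an effect only at larger amounts of compound. Compound 1, `O=C1CC(c2ccccc2)n2ccnc2N1`, gives 68.2 mg/kg in this assay. Compound 2, `O=C1CC(c2ccccc2F)n2ccnc2N1`, differs from compound 1 by one change, (fluoro in place of hydrogen on an aromatic carbon). In this assay compound 2 gives 88 mg/kg. The step from compound 1 to compound 2 is a 1.3-fold higher number from compound 1 to compound 2 (0.11 log units; within the scatter), so the two values cannot be told apart with confidence.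

Compound 3, `O=C1CC(c2ccccc2)n2nccc2N1`, has the same atoms as compound 1 but joined differently in the core; how the two cores differ is not broken down here. In this assay compound 3 gives 47.3 mg/kg. Its number and that of compound 1 sit within the usual scatter of each other, so no ordering between them is claimed.

Compound 4, `O=C1CC(c2ccccc2F)n2nccc2N1`, stands to compound 3 as compound 2 stands to compound 1: the change is fluoro in place of hydrogen on an aromatic carbon, and the place is described in the same words for both pairs, so it is the same change made on a different core. It has not yet been measured in this assay. Among the measured compounds shown here, because the only precedent, a 1.3-fold higher number from compound 1 to compound 2 (0.11 log units; within the scatter), was a small step within the scatter, a similarly small step is expected from compound 3 to compound 4, roughly a 1.3-fold higher number from compound 3 to compound 4 (0.10 log units; within the scatter). On that basis compound 4 is estimated to give about 60 mg/kg in this assay, most likely between 35 mg/kg and 105 mg/kg.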

Compound 4, dose for half-maximal effect: 47.3 mg/kg
Compound 4: middle estimate off by 1.3-fold (0.10 log units), on the high side; low and high end bracket the measured number.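

In this assay, placing fluoro in place of hydrogen on an aromatic carbon, ortho to a large group, gives no change at the digits printed from compound 3 to compound 4 (within the scatter), so this swap leaves no readable mark on the second core. Set beside the same swap on the first core, the new step cannot be told apart from the earlier one: the same change on two cores in this assay, a 1.3-fold higher number (0.11 log units; within the scatter) from compound 1 to compound 2 and no change at the digits printed (within the scatter) from compound 3 to compound 4, 1.3-fold (0.11 log units) apart, within the scatter of two such steps. This shows that the change behaves alike on these two cores, in the limited sense that its step stays within the scatter on both, but it does not show that fluoro is without any effect, since a small real shift could hide inside that scatter, and two pairs say nothing about other cores.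

On these data alone, the phenyl ring in these four compounds carries only hydrogen or fluoro, so it remains open whether a larger group at the same place, such as trifluoromethyl, methoxy or an amine, would move the number beyond the scatter on either core. A stricter test of carrying a change from one core to another would need such a step, one large enough to read, so that its size could be compared between the two cores.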